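A few compounds are considered here, and "the series" means these few. Any claim that something is new, unique, unknown or untested is made for them only; others in the source may bear on it.

Measured so far:

Compound 1, `CC(=O)N[C@@H]1CCC[C@H](C(=O)Nc2cc(-c3cnn4c3CC(C)(C)CC4)ccn2)C1`. In an ADME assay on microsomes from liver (Homo sapiens) for metabolic stability (a higher number here means faster removal of the compound, a lower number slower removal), compound 1 gives 29 mL.min-1.g-1.

Compound 2, `CC(=O)N[C@@H]1CCC[C@H](C(=O)Nc2cc(-c3cnn4c3CC(C)(C)CC4)c(F)cn2)C1`. In this assay compound 2 gives 178 mL.min-1.g-1.

Compound 3, `CC(=O)N[C@@H]1CCC[C@H](C(=O)Nc2cc(-c3cnn4c3CC(C)(C)C4)ccn2)C1`. In this assay compound 3 gives < 3 mL.min-1.g-1, which is a limit of the assay and not a number.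

Compounds 1 and 2 share one core and differ in a single place: fluoro in place of hydrogen on an aromatic carbon. That change produced a 6.1-fold higher number from compound 1 to compound 2 (0.79 log units; beyond the scatter), so the fluoro-bearing compound is cleared more quickly in this assay than its hydrogen-bearing partner.

Compound 3 is built on a different core. How the two cores differ is not broken down here. What is known of compound 3 is that it sits at the limit of < 3 mL.min-1.g-1 in this assay, at which 1 of the 3 values shown sits, so only an upper bound is available for it.

Compound 4, `CC(=O)N[C@@H]1CCC[C@H](C(=O)Nc2cc(-c3cnn4c3CC(C)(C)C4)c(F)cn2)C1`, has not yet been measured in this assay. It stands to compound 3 exactly as compound 2 stands to compound 1: fluoro in place of hydrogen on an aromatic carbon. The surroundings of the change are described in the same words in both pairs, so this is the same change made on a second core.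

If the change behaves on compound 3 as it did on compound 1, compound 4 is expected to show an at least 2.6-fold higher number from compound 3 to compound 4 (0.42 log units; beyond the scatter), a step of about the size seen as a 6.1-fold higher number from compound 1 to compound 2 (0.79 log units; beyond the scatter). Because compound 3 is known only as < 3 mL.min-1.g-1, the starting point is uncertain, and compound 4 may itself remain at the limit. The estimate for compound 4 in this assay is 8 mL.min-1.g-1, between 2 mL.min-1.g-1 and 25 mL.min-1.g-1.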

Compound 4, intrinsic clearance in microsomes in the Homo sapiens assay: 19 mL.min-1.g-1
Estimate against measurement, compound 4: 2.4-fold (0.38 log units) below, and the stated range covers the measured number.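

In the Homo sapiens assay compound 4 gives 19 mL.min-1.g-1, and fluoro in place of hydrogen on the aromatic carbon gave an at least 6.3-fold higher number from compound 3 to compound 4 (0.80 log units; beyond the scatter), so on the second core the change pushed removal in the same direction as on the first. Set side by side, the two results read: the same change on two cores in the Homo sapiens assay, a 6.1-fold higher number (0.79 log units; beyond the scatter) from compound 1 to compound 2 and an at least 6.3-fold higher number (0.80 log units; beyond the scatter) from compound 3 to compound 4; the limit leaves it open whether they differ In the Homo sapiens assay compound 3 gives < 3 mL.min-1.g-1, which is a limit of the assay and not a number, so the step on this core has a known minimum but no known size, and the data cannot say whether the change has the same effect on both cores.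

In a physicochemical assay for lipophilicity, using the shake flask method, measured as octanol-water partition, at pH 7.4 (a lower number here means a more polar compound, a higher number a more lipophilic compound), compound 3 gives 2.8 and compound 4 gives 3.3, and the same change gave a number 0.50 log units higher from compound 3 to compound 4 (beyond the scatter), but a single pair of compounds cannot tell whether this shift is connected with the faster removal in the Homo sapiens assay. On these data alone, it also remains open whether the rise in removal is particular to fluoro or would also follow from another group on the same carbon, such as chloro, methyl, a nitrile or an amine, and whether it would appear on a third core.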